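The source may report more compounds than this note shows. Statements on the series, on what has been measured and on what is new or still open speak of the compounds shown alone.

Compounds measured so far:

compound 1 `CCCCNc1nc(N)nc2c1CN(C(=O)C1CCC1)CC2` — in an assay on HEK293 cells for agonist activity at Toll-like receptor 8 (Homo sapiens), read by a luciferase reporter, with a stated time of 6 h (on this read-out lower numbers stand for an effect already at smaller amounts and higher numbers for an effect only at larger amounts of compound), compound 1 gives 0.4 uM
compound 2 `CCCCNc1nc(N)nc2c1CN(C(=O)c1cnc(C)cn1)CC2` — in this assay compound 2 gives 6.8 uM

For the measured compounds named here, compound 2 stands at the higher of the two numbers in this assay; its only neighbour is compound 1, and the step of a 17-fold higher number from compound 1 to compound 2 (1.23 log units; beyond the scatter) is large and beyond the scatter. Compound 3 `CCCCNc1nc(N)nc2c1CN(C(=O)c1csc(C)n1)CC2` is not yet measured. It differs from compound 2 by 2-methyl-1,3-thiazol-4-yl in place of 5-methylpyrazin-2-yl on a carbonyl carbon. Going by the values given here, the one measured step exchanges cyclobutyl for 5-methylpyrazin-2-yl at the same carbonyl carbon, so it tells only that an aromatic group in this place gave a higher number than cyclobutyl; no step compares two such aromatic groups with each other. The change to compound 3 is therefore expected to give a step in this assay no larger than the scatter, with a slight lean toward a lower number, a 1.7-fold lower number from compound 2 to compound 3 (0.23 log units; within the scatter). Compound 3 is estimated at 4 uM, within a range from 1 uM to 15 uM.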

Compound 3, minimum effective concentration: 1.8 uM
Compound 3: the middle estimate sits 2.2-fold (0.35 log units) above what was measured; measured number inside the range.
By their numbers in this assay, from the lowest: compound 1; then compound 3; then compound 2.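

In this assay, 2-methyl-1,3-thiazol-4-yl in place of 5-methylpyrazin-2-yl on the carbonyl carbon gives a lower number (a 3.8-fold lower number from compound 2 to compound 3 (0.58 log units; beyond the scatter)), so this position separates two aromatic groups from each other and not only an aromatic group from cyclobutyl. The new group still does not match cyclobutyl (a 4.5-fold higher number from compound 1 to compound 3 (0.65 log units; beyond the scatter)), and among these three compounds cyclobutyl retains the lowest number, with neither aromatic compound going against that order. Nothing shown accounts for the difference between the two aromatic groups.

For the compounds shown here, it remains open whether the methyl on the 2-methyl-1,3-thiazol-4-yl group contributes to this result, since no compound carries that ring without it. Also open, going by these compounds, is how a cyclopentyl group or a straight butyl chain on the same carbonyl carbon would compare with cyclobutyl.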